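This account rests on a few compounds, and the source may have more. Where it says the series, first, only, none or still open, it means among the compounds named here.

Compound 1 `COc1cc(-c2nccn3cc(-c4ccc5[nH]ccc5c4)nc23)cc(OC)c1OC`: 23 nM
Compound 2 `COc1cc(-c2nccn3cc(-c4ccc(C(F)(F)F)cc4)nc23)cc(OC)c1OC`: > 10000 nM

Both compounds were tested in a functional assay on HCT-116 cells (Homo sapiens) for inhibition, read by MTT assay, with a stated time of 48 h; a lower number here means a stronger inhibitor, a higher number a weaker inhibitor. Compound 2 gives only a limit of the assay, not a number: > 10000 nM. This places it at the limit of > 10000 nM in this assay, at which 1 of the 2 values shown sits.

Compound 3 `COc1cc(-c2nccn3cc(-c4ccc(O)cc4)nc23)cc(OC)c1OC` differs from compound 2 by hydroxy in place of trifluoromethyl on an aromatic carbon, para to a large group: hydroxy in place of trifluoromethyl on an aromatic carbon.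

Going by the values given here, the one measured step bearing on this change is an at least 430-fold higher number from compound 1 to compound 2 (2.63 log units; beyond the scatter), which came with 4-(trifluoromethyl)phenyl in place of 1H-indol-5-yl on an aromatic carbon. That large step shows that this site can move the read-out strongly, although it does not involve hydroxy. A clear step towards a lower number is therefore expected, with only part of the gap to compound 1 recovered.

The expected change is an at least 12-fold lower number from compound 2 to compound 3 (1.09 log units; beyond the scatter). The estimate for compound 3 is 800 nM, with an expected range of 60 nM to 10000 nM.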

Compound 3, half-maximal inhibitory concentration: 901 nM
The estimate for compound 3 lay 1.1-fold (0.05 log units) below the measured number, and the stated range covers the measured number.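

In this assay, exchanging trifluoromethyl for hydroxy on the phenyl ring, with the rest of the molecule unchanged, gives an at least 11-fold lower number from compound 2 to compound 3 (1.04 log units; beyond the scatter), so a single substituent at this place moves the read-out strongly without any change to the ring itself. From the compounds shown here alone, the true size of that step stays unknown, since compound 2 stands at a limit, not a number: the limit of > 10000 nM in this assay, at which 1 of the 3 values shown sits. The 4-hydroxyphenyl group still does not match the 1H-indol-5-yl group, with a 39-fold higher number from compound 1 to compound 3 (1.59 log units; beyond the scatter), so hydroxy recovers only part of the activity of compound 1.

An amine or a carboxylic acid on the same carbon would test whether the gain is specific to hydroxy. Going by these compounds, how much of the remaining gap to compound 1 a group at this place can close stays open.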